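A Smaller Side Group on the Amine Nitrogen of Compound 2

This account rests on a few compounds, and the source may have more. Where it says the series, first, only, none or still open, it means among the compounds named here.

Among the measured compounds shown here, in a functional assay on the whole organism with Rattus norvegicus as the target, at a dose of 100 mg/kg (a higher number here means more inhibition at the dose given (going by the name of the read-out), a lower number less inhibition), compound 2 `C=CCNC(=S)NCCCCn1nc(-c2ccccc2)ccc1=O` gives 27.1%, the lowest of the two numbers so far; its nearest neighbour, compound 1 `N#CNC(=N)NCCCCCn1nc(-c2ccccc2)ccc1=O`, gives 31%, and the step of a number 3.9 percentage points lower from compound 1 to compound 2 (within the scatter) lies within the scatter. The unmeasured compound 3 `CC/N=C(\S)NCCCCn1nc(-c2ccccc2)ccc1=O` differs from compound 2 in one place: a group of 5 heavy atoms (3 carbon, 1 nitrogen, 1 sulfur; no ring) in place of a group of 6 heavy atoms (4 carbon, 1 nitrogen, 1 sulfur; no ring), on an amine nitrogen. For the measured compounds named here, only one measured step exists, and it sits elsewhere in the molecule, on a saturated chain carbon, so it bears on the change to compound 3 only in showing that exchanging one side group left this assay unchanged within the scatter. Nothing in the two measured values points to a move beyond the scatter from compound 2 to compound 3, so no direction is expected for the new compound, and the uncertainty is simply that of a single measurement of this kind. The expected step is a number 0.1 percentage points lower from compound 2 to compound 3 (within the scatter). Compound 3 is therefore estimated at 27%, within a range from 12% to 42%.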

Compound 3, a percentage reported as inhibition, in the whole organism at one dose (the size of the read-out at that dose, not a potency): 67.7%
Compound 3: middle estimate off by 40.7 percentage points, on the low side, outside the stated range (above it).
By their numbers in this assay, from the lowest: compounds 2 and 1 (each within the scatter of the next); then compound 3.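

In this assay, the group on the amine nitrogen turns out not to be a neutral place in this series: a group of 5 heavy atoms in place of a group of 6 heavy atoms, with one double bond outside aromatic rings where there were two and the same count of hydrogen-bond donors and acceptors, gives a number 40.6 percentage points higher from compound 2 to compound 3 (beyond the scatter). Among the compounds shown here, the comparison with the other earlier compound points the same way, with a number 36.7 percentage points higher from compound 1 to compound 3 (beyond the scatter), so compound 3 stands clear of both, whereas the only earlier step had stayed within the scatter and had given no sign that a side-group exchange could move this read-out so far. Nothing available accounts for this rise.

The compounds shown cannot separate the effect of the smaller group from that of losing a double bond, and a methyl or a propyl group on the same amine nitrogen would bear on that question. They also leave open whether the rise would hold with a longer chain to the core or with a phenyl ring on that nitrogen, and how the number behaves at other doses.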